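Cyclopropyl for cyclobutyloxy on the pyrimidine of compound 2

The source may hold more compounds than are shown below. What is called first, only, known or untested is meant among the compounds shown, and "the series" means these compounds.

Two members of the series carry a number in a functional assay on U2OS cells for antagonist activity at C-X-C chemokine receptor type 3 (Homo sapiens), read by beta-arrestin recruitment (on this read-out lower numbers stand for stronger inhibition and higher numbers for weaker inhibition), so far. Compound 1 `CCOc1ncc(-c2nc(C(F)(F)F)sc2N2CCN(C(=O)Cn3cnc(C(F)(F)F)n3)[C@H](C)C2)cn1` gives 118 nM in this assay. Compound 2 `Cc1nc(C)n(CC(=O)N2CCN(c3sc(C(F)(F)F)nc3-c3cnc(OC4CCC4)nc3)C[C@H]2C)n1` gives 78 nM in this assay. For the measured compounds named here, compound 2 holds the lower of the two numbers, but its only neighbour, compound 1, sits within the usual scatter of it, so the two read as equivalent in this assay and no order can be drawn from them.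

Compound 3 `Cc1nc(C)n(CC(=O)N2CCN(c3sc(C(F)(F)F)nc3-c3cnc(C4CC4)nc3)C[C@H]2C)n1` is the next member and has no number yet. It differs from compound 2 in one place: cyclopropyl in place of cyclobutyloxy on an aromatic carbon. In words, cyclopropyl in place of cyclobutyloxy on an aromatic carbon; the group that leaves has five heavy atoms and one hydrogen-bond acceptor, the one that enters has three heavy atoms and no acceptor. Going by the values given here, no measured pair in the set changes this position, so the size of the step rests on the change alone. A modest weakening is expected, with the step from compound 2 to compound 3 estimated at a 2.3-fold higher number from compound 2 to compound 3 (0.36 log units; beyond the scatter) in this assay. Compound 3 is therefore estimated at 180 nM in this assay, with a range from 60 nM to 600 nM.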

Compound 3, half-maximal inhibitory concentration: 349 nM
Beside the measured number, compound 3's estimate is 1.9-fold (0.29 log units) below it; the range from low to high includes it.
By their numbers in this assay, from the lowest: compounds 2 and 1 (each within the scatter of the next); then compound 3.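

In this assay, replacing 2-(cyclobutyloxy)pyrimidin-5-yl with 2-cyclopropylpyrimidin-5-yl gives a 4.5-fold higher number from compound 2 to compound 3 (0.65 log units; beyond the scatter). For the compounds shown here, this is the first one-place comparison in the set, since compound 1 and compound 2 differ in more than one place and their closeness said nothing about this position. The group on the aromatic carbon between two ring nitrogen atoms therefore registers in this read-out, and here the cyclobutyloxy form holds the lower number, but no supporting measurement explains the step.

The oxygen atom and the ring size change together in this single step, so their contributions cannot be separated from compound 2 and compound 3 alone. Cyclopropyloxy and cyclobutyl at this same place would pull those two apart, while whether an amine such as dimethylamino is tolerated there remains open.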